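This account rests on a few compounds, and the source may have more. Where it says the series, first, only, none or still open, it means among the compounds named here.

Measured in a functional assay on BT-549 cells (Homo sapiens) for inhibition, read by sulforhodamine B assay, with a stated time of 48 h; a higher number here means a weaker inhibitor of growth, a lower number a stronger inhibitor of growth:

Compound 1, `COc1ccc(-c2cc(/C=C/C(=O)c3ccc(N)cc3)[nH]n2)cc1`: 4780 nM
Compound 2, `COc1ccc(C(=O)/C=C/c2cc(-c3cc(OC)c(OC)c(OC)c3)n[nH]2)cc1OC`: 2900 nM
Compound 3, `COc1ccc(-c2cc(/C=C/C(=O)c3ccc(N)cc3)[nH]n2)cc1OC`: 2940 nM

Compound 1 and compound 3 share one core and differ in a single place, (methoxy in place of hydrogen on an aromatic carbon). That change gave a 1.6-fold lower number from compound 1 to compound 3 (0.21 log units; within the scatter). Compound 2 stands on a different core; how the core of compound 2 differs from the core of compound 1 is not broken down here. Its value sits within the scatter of both compound 1 and compound 3, so no order among the three can be read from these numbers.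

Compound 4, `COc1cc(C(=O)/C=C/c2cc(-c3cc(OC)c(OC)c(OC)c3)n[nH]2)cc(OC)c1OC`, has not yet been measured in this assay. It arises from compound 2 by methoxy in place of hydrogen on an aromatic carbon. This is the same kind of change as that from compound 1 to compound 3, though the surroundings are not identical: in compound 4 the entering methoxy is also meta to a methoxy group, which is not the case in compound 3.

Because the earlier step of a 1.6-fold lower number from compound 1 to compound 3 (0.21 log units; within the scatter) stayed within the scatter, compound 4 is expected to lie close to compound 2, with a step of about a 1.3-fold lower number from compound 2 to compound 4 (0.10 log units; within the scatter). The estimate for compound 4 in this assay is 2300 nM, with a likely range from 900 nM to 6000 nM.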

Compound 4, concentration for total growth inhibition: 2960 nM
Beside the measured number, compound 4's estimate is 1.3-fold (0.11 log units) below it, within the range that was stated.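

In this assay, methoxy in place of hydrogen on an aromatic carbon gave a 1.0-fold higher number from compound 2 to compound 4 (0.01 log units; within the scatter), so on the core of compound 2 this change produced no readable shift. Set beside the earlier step on the core of compound 1, the change gives no sign of behaving differently on the two cores: the same change on two cores in this assay, a 1.6-fold lower number (0.21 log units; within the scatter) from compound 1 to compound 3 and a 1.0-fold higher number (0.01 log units; within the scatter) from compound 2 to compound 4, 1.7-fold (0.22 log units) apart, within the scatter of two such steps

This agreement is a weak one: neither step stands clear of the scatter, so the two cores share only the absence of a readable effect, and the comparison cannot show that a real effect of the methoxy group carries from one core to the other. It also rests on just two pairs whose surroundings are not identical, since the entering methoxy in compound 4 is ortho to a methoxy group and meta to a methoxy group, and it cannot be extended to other cores in the series.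

The compounds shown leave open whether anything other than methoxy at this place on an aromatic carbon would move the number beyond the scatter. A hydroxyl group, a fluorine atom or a longer chain such as ethoxy could be informative there, on either core.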